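A few compounds are considered here, and "the series" means these few. Any claim that something is new, unique, unknown or untested is made for them only; others in the source may bear on it.

In a functional assay on U-937/GTB cells (Homo sapiens) for cytotoxicity (on this read-out lower numbers stand for stronger inhibition and higher numbers for weaker inhibition), the series shares one core and varies the chain on its charged nitrogen. Compound 1 `C=CC[n+]1cn(C)c2nc[nH]/c(=N\OC)c21` reaches only a limit, > 80000 nM. Compound 2 `CO/N=c1\[nH]cnc2c1[n+](Cc1ccccc1)cn2C` also reaches only a limit, > 80000 nM. Going by the values given here, compound 3 `CO/N=c1\[nH]cnc2c1[n+](C/C=C(\C)CCC=C(C)C)cn2C` gives 17500 nM, the only actual number among the three, so its distance from the other two cannot be sized.

Compound 4 `CO/N=c1\[nH]cnc2c1[n+](C/C=C(\C)CC/C=C(\C)CCC=C(C)C)cn2C` extends the chain of compound 3: 3-methylbut-2-en-1-yl in place of hydrogen on a saturated chain carbon bound to a double-bonded chain carbon. In words, 3-methylbut-2-en-1-yl stands in place of hydrogen on a saturated chain carbon bound to a double-bonded chain carbon.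

Among the compounds with values here, no measured step matches this change. Within the data shown here, the only step available, a step that the two limits leave unreadable from compound 1 to compound 2, has no readable size and gives no direct guide. Among the measured compounds shown here, the sole indication is that compound 3, with the chain being extended here, yields a number at 17500 nM. The other two compounds yield only limits. Three compounds make a thin basis, so the expectation is a cautious one. The expected change, a 2.9-fold lower number from compound 3 to compound 4 (0.46 log units; beyond the scatter), is a moderate one towards stronger inhibition. Compound 4 is estimated at 6000 nM, with an expected range from 1500 nM to 20000 nM.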

Compound 4, half-maximal inhibitory concentration: 1320 nM
Compound 4: the middle estimate sits 4.5-fold (0.66 log units) above what was measured, outside the stated range (below it).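

In this assay, going by these compounds alone, placing 3-methylbut-2-en-1-yl on a saturated chain carbon bound to a double-bonded chain carbon gives a 13-fold lower number from compound 3 to compound 4 (1.12 log units; beyond the scatter), the first step whose size can be read. It shows that this position still responds when the chain is extended, and that an entering group of 5 heavy atoms, all carbon, with no ring and 1 double bond, moves the read-out clearly towards stronger inhibition. The earlier compounds could not show the size of any change, since the step between compound 1 and compound 2 cannot be read, because each of these two compounds stands at a limit: the limit of > 80000 nM in this assay, at which 2 of the 4 values shown sit.

The compounds shown leave open whether a longer chain built from a further 3-methylbut-2-en-1-yl unit would lower the number again or whether the gain ends at compound 4. They also leave open whether the double bonds in the chain matter, as a fully saturated chain of the same length would test, and how a chain ending in an amine or a carboxylic acid would read in this assay.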